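This account rests on a few compounds, and the source may have more. Where it says the series, first, only, none or still open, it means among the compounds named here.

Measured compounds:
Compound 1 `Cc1nc(NC(C)C)c2cnn(-c3ccccc3)c2n1` gives > 100000 nM in a functional assay on G-361 cells (Homo sapiens) for cytotoxicity, read by sulforhodamine B assay (a lower number here means a stronger inhibitor of growth, a higher number a weaker inhibitor of growth), which is a limit of the assay and not a number.
Compound 2 `CCCCNc1nc(C)nc2c1cnn2-c1ccccc1` gives > 100000 nM in this assay, likewise a limit.

Among the measured compounds shown here, the single measured step, a step that the two limits leave unreadable from compound 1 to compound 2, cannot be read because both ends sit at the limit of > 100000 nM in this assay, at which 2 of the 2 values shown sit. For the measured compounds named here, compound 1 therefore stands only at a limit in this assay, with no number placing it more precisely, and the one further value shown is a limit as well.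

Compound 3 `CC(C)NCc1nc(NC(C)C)c2cnn(-c3ccccc3)c2n1` differs from compound 1 by isopropylamino in place of hydrogen on a saturated chain carbon bound to an aromatic carbon. Going by the values given here, no measured step bears on this change: the only step available concerns the substituent on the ring nitrogen and is itself unreadable, and no measured compound varies the methyl. The expectation for compound 3 rests on the two limits alone.

Compound 3 is accordingly expected at 150000 nM, with a range from 30000 nM to 1000000 nM, and most probably reported again as a limit. The implied step that the limit leaves unreadable from compound 1 to compound 3 is expected to lie within the scatter.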

Compound 3, concentration for total growth inhibition: > 100000 nM
Compound 3: only a limit was reported (the forecaster's own chance of this, stated with the estimate: 80%); the middle value lies beyond the limit too.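

Compound 1 and compound 3 both stand only at a limit in this assay, so no new step can be read between them: the limit of > 100000 nM in this assay, at which 3 of the 3 values shown sit.

The compounds shown leave open which change to the shared core, if any, would give a value that is a number rather than a limit.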